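The source may report more compounds than this note shows. Statements on the series, on what has been measured and on what is new or still open speak of the compounds shown alone.

Two sulfonamides built on a shared core have been measured in an assay on cells for inhibition of HSP60/HSP10 (Homo sapiens), with a stated time of 60 min; a lower number here means a stronger inhibitor, a higher number a weaker inhibitor. Compound 1 `O=S(=O)(Nc1ccc(-c2nc3ccccc3o2)cc1)c1ccc(Cl)c(C(F)(F)F)c1` carries a chloro and trifluoromethyl substituted phenyl on the sulfonyl sulfur, and in this assay compound 1 gives 12000 nM. Compound 2 `CCc1ccc(S(=O)(=O)Nc2ccc(-c3nc4ccccc4o3)cc2)cc1` carries a 4-ethylphenyl there instead. For compound 2 the result in this assay is > 100000 nM, which is a limit of the assay rather than a number, as recorded in the limit of > 100000 nM in this assay, at which 1 of the 2 values shown sits. Compound 3 `O=S(=O)(Nc1ccc(-c2nc3ccccc3o2)cc1)c1ccc(Cl)c(Cl)c1` has not been measured; it differs from compound 2 in 3,4-dichlorophenyl in place of 4-ethylphenyl on a sulfonyl sulfur. For the measured compounds named here, no measured step between two compounds links this change to a known size, so the expectation rests only on the two values shown. Since compound 2 sits at a limit, the step of an at least 6.6-fold lower number from compound 2 to compound 3 (0.82 log units; beyond the scatter) is expected to move toward stronger inhibition, but its size is uncertain. Compound 3 is estimated at 15000 nM, with a range from 4000 nM to 60000 nM.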

Compound 3, half-maximal inhibitory concentration: 25000 nM
Estimate against measurement, compound 3: 1.7-fold (0.22 log units) below, and the stated range covers the measured number.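

Putting 3,4-dichlorophenyl in place of 4-ethylphenyl on the sulfonyl sulfur gives an at least 4.0-fold lower number from compound 2 to compound 3 (0.60 log units; beyond the scatter) in this assay, so the substituents on this phenyl ring clearly affect the read-out. The value of compound 2 is a limit and not a number, so this step has a known minimum but no known full size: the limit of > 100000 nM in this assay, at which 1 of the 3 values shown sits. Chloro in place of trifluoromethyl on an aromatic carbon gives a 2.1-fold higher number from compound 1 to compound 3 (0.32 log units; beyond the scatter), a modest step that shows that compound 1 and compound 3, both with chlorine-bearing rings, give measured values, with the trifluoromethyl compound the stronger of the two.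

The compounds shown leave open how a phenyl ring with a single chloro would compare with compound 3, and how an amine or a carboxylic acid on this ring would fare. They also say nothing about changes to the shared core.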